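The source may hold more compounds than are shown below. What is called first, only, known or untested is meant among the compounds shown, and "the series" means these compounds.

Compound 1 `CCC(C)C1NC(=O)N(C2CCCCC2)C1=O`: in a functional assay on SW-620 cells (Homo sapiens) for inhibition (a higher number here means a weaker inhibitor, a lower number a stronger inhibitor), compound 1 gives > 100000 nM, which is a limit of the assay rather than a number. Compound 3 `CC(C)C1NC(=O)N(C2CCCCC2)C1=O`: compound 3 gives > 100000 nM, likewise a limit. Compound 2 `CC(C)C(NC(=O)n1nnc2ccccc21)C(=O)NC1CCCC1`: compound 2 gives > 200000 nM, also a limit.

Compound 3 and compound 1 share one core and differ by methyl in place of hydrogen on a saturated chain carbon, two bonds along the chain from a saturated ring carbon. The step that the two limits leave unreadable from compound 3 to compound 1 cannot be sized because both values sit at the limit of > 100000 nM in this assay, at which 2 of the 3 values shown sit. Compound 2 carries a different core; the difference between the two cores is not broken down here. Compound 4 `CCC(C)C(NC(=O)n1nnc2ccccc21)C(=O)NC1CCCC1` differs from compound 2 by methyl in place of hydrogen on a saturated chain carbon, three bonds along the chain from an amide-type nitrogen and a carbonyl carbon. It is the same kind of change, though here the place is three bonds along the chain from an amide-type nitrogen and a carbonyl carbon, not two bonds from a saturated ring carbon. Compound 2 sits at the limit of > 200000 nM in this assay, at which 1 of the 3 values shown sits. With no readable step anywhere, compound 4 is expected to remain at a limit, around 200000 nM. The step of a number no higher from compound 2 to compound 4 (the limit leaves the size open) is expected to be unreadable in the same way.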

Compound 4, half-maximal inhibitory concentration: > 100000 nM
Compound 4 gave a limit, no number (the forecaster's own chance of this, stated with the estimate: 90%); the middle value lies beyond the limit too.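

Compound 2 and compound 4 both give only limits, not numbers, so no step can be read between them. The compounds shown leave open what actual value any of these four structures would reach in this assay.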